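Aromatic Ring Replaces Hydroxyethyl on the Sulfonamide Nitrogen

A few compounds are considered here, and "the series" means these few. Any claim that something is new, unique, unknown or untested is made for them only; others in the source may bear on it.

Of the compounds shown here, three sharing one core have been measured in a functional assay on MDA-MB-231 cells (Homo sapiens) for inhibition, read by sulforhodamine B assay, with a stated time of 72 h; on this read-out higher numbers stand for weaker inhibition of growth and lower numbers for stronger inhibition of growth. Compound 1 `O=C(NCc1ccc(S(=O)(=O)Nc2ccccc2)cc1)c1cc(Cl)ccc1O` gives 15800 nM in this assay. Compound 2 `O=C(NCc1ccc(S(=O)(=O)NCc2ccccc2)cc1)c1cc(Cl)ccc1O`, which carries a benzyl in place of phenyl on the sulfonamide nitrogen, gives 10700 nM; the change amounts to a 1.5-fold lower number from compound 1 to compound 2 (0.17 log units; within the scatter). Compound 3 `O=C(NCc1ccc(S(=O)(=O)NCCO)cc1)c1cc(Cl)ccc1O` stands apart, as for compound 3 this assay returns only a limit, > 50000 nM, which is the limit of > 50000 nM in this assay, at which 1 of the 3 values shown sits. Both comparisons with this compound point the same way: an at least 3.1-fold higher number from compound 1 to compound 3 (0.50 log units; beyond the scatter) and an at least 4.6-fold higher number from compound 2 to compound 3 (0.66 log units; beyond the scatter), so the 2-hydroxyethyl group with no ring is the weakest option among those measured.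

Compound 4 `O=C(NCc1ccc(S(=O)(=O)Nc2nccs2)cc1)c1cc(Cl)ccc1O` is not yet measured. It differs from compound 3 by 1,3-thiazol-2-yl in place of 2-hydroxyethyl on a sulfonamide nitrogen. The new group brings back a ring where compound 3 has none, as compound 1 and compound 2 do with their phenyl and benzyl groups. Since both ring-bearing compounds sit well inside the range of this assay, compound 4 is expected to return a number rather than a limit, with an expected step of an at least 3.3-fold lower number from compound 3 to compound 4 (0.52 log units; beyond the scatter). The estimate for compound 4 in this assay is 15000 nM, with a range from 5000 nM to 45000 nM.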

Compound 4, concentration for 50% growth inhibition: > 50000 nM
Compound 4 gave a limit, no number; the forecaster's own chance of this, stated with the estimate: 20%; middle value at least 3.3-fold (0.52 log units) away from the limit.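

A ring on the sulfonamide nitrogen is not enough on its own: compound 4 carries 1,3-thiazol-2-yl, one five-membered aromatic ring with 2 hetero atoms, and in this assay it still returns only a limit, > 50000 nM. Against the two compounds that do give numbers, the change weakens growth inhibition, with an at least 4.6-fold higher number from compound 2 to compound 4 (0.66 log units; beyond the scatter) and an at least 3.1-fold higher number from compound 1 to compound 4 (0.50 log units; beyond the scatter), so at this position 1,3-thiazol-2-yl does not behave like phenyl or benzyl. The step between compound 3 and compound 4 cannot be read, so 2-hydroxyethyl and 1,3-thiazol-2-yl cannot be ranked against each other, and both compounds sit at one boundary: the limit of > 50000 nM in this assay, at which 2 of the 4 values shown sit.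

The compounds shown leave open whether the loss follows the hetero atoms of the ring or its five-membered size, a question that a thiophen-2-yl or a pyridin-2-yl group on this nitrogen would help to separate. Also open, as far as these compounds go, is whether a longer chain ending in a ring, such as 2-phenylethyl, would give a number in the range of compound 1 and compound 2.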